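A few compounds are considered here, and "the series" means these few. Any claim that something is new, unique, unknown or untested is made for them only; others in the source may bear on it.

Working notes on the series. Compound 1 is `Cc1cc(C=C(C#N)C#N)c(C)n1-c1cccc(-c2nnn[nH]2)c1`. In an ADME assay on MT2 cells (Homo sapiens) for cytotoxicity, read by XTT assay, with a stated time of 4 days (a higher number here means that more compound is tolerated, a lower number that less compound is tolerated), compound 1 returns only a limit, > 400000 nM, with no number. That limit is where the series starts, (the limit of > 400000 nM in this assay, at which 1 of the 2 values shown sits). Compound 2 is `Cc1cc(/C=C2\SC(=S)N(c3cccc(C(F)(F)F)c3)C2=O)c(C)n1-c1cccc(-c2nnn[nH]2)c1`. In this assay, among the compounds with values here, compound 2 gives 15800 nM, the only numerical value recorded so far. Within the data shown here, compound 1 returned only a limit, so no measured step between two numbers exists and nothing can be said about a trend.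

Compound 3 is `COc1ccc(N2C(=O)/C(=C/c3cc(C)n(-c4cccc(-c5nnn[nH]5)c4)c3C)SC2=S)cc1`. Relative to compound 2 the change is 4-methoxyphenyl in place of 3-(trifluoromethyl)phenyl on an amide-type nitrogen in a ring. Among the measured compounds shown here, no measured pair differing in one place is available, so the size of the step has to be guessed. The expectation is for a modest shift toward more compound being tolerated, though a step of this kind could well stay within the scatter. The estimate for compound 3 in this assay is 25000 nM, with a range from 8000 nM to 80000 nM. That estimate corresponds to an expected step of a 1.6-fold higher number from compound 2 to compound 3 (0.20 log units; within the scatter).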

Compound 3, half-maximal cytotoxic concentration: 87000 nM
Estimate against measurement, compound 3: 3.5-fold (0.54 log units) below; measured number outside the range, above it.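

In this assay, the first measured pair differing in one place gives a 5.5-fold higher number from compound 2 to compound 3 (0.74 log units; beyond the scatter), so more compound is tolerated with 4-methoxyphenyl than with 3-(trifluoromethyl)phenyl on the amide-type nitrogen in a ring. Within the data shown here, this shows that the aryl group at this position can move the read-out beyond the usual scatter, even though the six-membered aromatic ring of carbon stays in place and only its substituent changes; the earlier compounds offered no such reading for any position. The pair gives a size and a direction for this one change, but no measured property accompanies it, so nothing here accounts for the step.

Still open, going by these compounds, is whether the step follows the identity of the substituent or its place on the phenyl ring, as the two groups differ in both; a 3-methoxyphenyl or a 4-(trifluoromethyl)phenyl at the same nitrogen would separate these two readings. Also open, on these data alone, is how an unsubstituted phenyl, or a phenyl carrying an amine or a carboxylic acid, would stand relative to this pair.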